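A Carbamoyl Variant in a Sulfonamide Series

A few compounds are considered here, and "the series" means these few. Any claim that something is new, unique, unknown or untested is made for them only; others in the source may bear on it.

Compound 3 `O=C([C@@H]1CCCN1C(=O)c1ccncc1)N1CCC(NS(=O)(=O)c2cc(S(=O)(=O)c3ccccc3)ccc2C(F)(F)F)CC1` gives 70 nM in an assay on isolated protein for binding affinity to secreted frizzled-related protein 1 (Homo sapiens), read by fluorescence (a lower number here means a stronger inhibitor, a higher number a weaker inhibitor), the lowest of the three numbers shown, though its gap to compound 1 `CC(C)(C)OC(=O)N1CCC[C@@H]1C(=O)N1CCC(NS(=O)(=O)c2cc(S(=O)(=O)c3ccccc3)ccc2C(F)(F)F)CC1`, which gives 120 nM, lies within the scatter; compound 2 `CC(=O)N1CCC[C@H]1C(=O)N1CCC(NS(=O)(=O)c2cc(S(=O)(=O)c3ccccc3)ccc2C(F)(F)F)CC1` gives 160 nM. Compound 4 `CC(C)(C)NC(=O)N1CCC[C@H]1C(=O)N1CCC(NS(=O)(=O)c2cc(S(=O)(=O)c3ccccc3)ccc2C(F)(F)F)CC1` carries (tert-butyl)amino in place of pyridin-4-yl on a carbonyl carbon. Within the data shown here, two measured steps touch this carbonyl: a 1.3-fold higher number from compound 1 to compound 2 (0.12 log units; within the scatter) and a 2.3-fold lower number from compound 2 to compound 3 (0.36 log units; beyond the scatter). The first shows that exchanging one acyl group for another here can leave the number unchanged; the second shows the modest gain that the pyridin-4-yl brought, which compound 4 gives up. Compound 4 is therefore expected to show a 1.7-fold higher number from compound 3 to compound 4 (0.23 log units; within the scatter), returning toward the numbers of compound 1 and compound 2. Compound 4 is estimated at 120 nM, within 60 nM to 250 nM.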

Compound 4, half-maximal inhibitory concentration: 20 nM
Beside the measured number, compound 4's estimate is 6.0-fold (0.78 log units) above it; measured number below the stated range.
By their numbers in this assay, from the lowest: compound 4; then compounds 3, 1 and 2 (each within the scatter of the next, the first and the last beyond it).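

In this assay, (tert-butyl)carbamoyl on this ring nitrogen's carbonyl carbon stands apart from all three other acyl groups shown: a 3.5-fold lower number from compound 3 to compound 4 (0.54 log units; beyond the scatter), an 8.0-fold lower number from compound 2 to compound 4 (0.90 log units; beyond the scatter) and a 6.0-fold lower number from compound 1 to compound 4 (0.78 log units; beyond the scatter). Among these compounds, the position can therefore give a larger gain than the earlier steps showed, and that gain came with a hydrogen-bond donor entering as pyridin-4-yl left. No measurement shown accounts for the gain. As far as these compounds go, whether it follows the amide hydrogen or the tert-butyl group remains open. A dimethylamino or a 2,2-dimethylpropyl group on this carbonyl carbon would separate the two.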